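Pyrrolidinyl in Place of Ethoxy on a Sub-Nanomolar Acylurea

A few compounds are considered here, and "the series" means these few. Any claim that something is new, unique, unknown or untested is made for them only; others in the source may bear on it.

Among the compounds with values here, compound 1, `CCOc1ccc(Cl)c(C(=O)NC(=O)Nc2nc3ccc(S(=O)(=O)CCCN4CCN(C)CC4)cc3s2)c1`, is the stronger of the two compounds so far tested in an assay on HEK293 cells for displacement of a labelled ligand from growth hormone secretagogue receptor type 1 (Homo sapiens), with a stated time of 60 min; a lower number here means a stronger inhibitor, a higher number a weaker inhibitor. In this assay compound 1 gives 0.31 nM. Within the data shown here, the only other measured compound, compound 2, `CC(C)NCCS(=O)(=O)c1ccc2nc(NC(=O)NC(=O)c3ccccc3Cl)sc2c1`, gives 27 nM in this assay, a far higher number, and the gap between the two lies well beyond the scatter of repeated measurements.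

Compound 3, `CN1CCN(CCCS(=O)(=O)c2ccc3nc(NC(=O)NC(=O)c4cc(N5CCCC5)ccc4Cl)sc3c2)CC1`, has not yet been measured. It differs from compound 1 in a single place: pyrrolidin-1-yl in place of ethoxy on an aromatic carbon. Among the measured compounds shown here, no measured pair isolates a change of this kind, so the direction cannot be read from the data at hand. The author expects the step from compound 1 to compound 3 in this assay to be a 1.6-fold higher number from compound 1 to compound 3 (0.21 log units; within the scatter), which is to say no change beyond the scatter. Compound 3 is therefore expected to give 0.5 nM in this assay, with a range from 0.15 nM to 2 nM.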

Compound 3, half-maximal inhibitory concentration: 0.29 nM
The estimate for compound 3 lay 1.7-fold (0.24 log units) above the measured number; the measured number falls inside the stated range.
By their numbers in this assay, from the lowest: compounds 3 and 1 (each within the scatter of the next); then compound 2.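

In this assay, the change from ethoxy to pyrrolidin-1-yl, on an aromatic carbon para to a chloro group, gives a 1.1-fold lower number from compound 1 to compound 3 (0.03 log units; within the scatter) and so leaves the two compounds indistinguishable. Within the data shown here, this is the first measured pair to isolate this position, and it shows that a five-membered non-aromatic ring with 1 hetero atom can stand here in place of ethoxy with no change beyond the scatter. Among these compounds, nothing measured so far bears on why the two groups read alike.

The compounds shown leave open whether other groups on this carbon, such as methoxy, a carboxylic acid, a morpholin-4-yl group or a longer alkoxy chain, would also read alike. They also leave open whether the same exchange would read alike with fluoro in place of the chloro group.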